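Capping the aminomethyl: aryl sulfonyl to methyl sulfonyl

The source may report more compounds than this note shows. Statements on the series, on what has been measured and on what is new or still open speak of the compounds shown alone.

Compound 1 `CCCCc1ccc(CNC(=O)OC(C)(C)C)c(=O)n1Cc1ccc(-c2ccccc2-c2nn[nH]n2)cc1` gives 10 nM in a functional assay (aorta) for antagonist activity, with Oryctolagus cuniculus as the target; a lower number here means a stronger inhibitor, a higher number a weaker inhibitor. Compound 2 `CCCCc1ccc(CNS(=O)(=O)c2ccc(C)cc2)c(=O)n1Cc1ccc(-c2ccccc2-c2nn[nH]n2)cc1` gives 9 nM in this assay, and the step of a 1.1-fold lower number from compound 1 to compound 2 (0.05 log units; within the scatter) is within the scatter, so compound 2 stands level with compound 1. Compound 3 `CCCCc1ccc(CNS(C)(=O)=O)c(=O)n1Cc1ccc(-c2ccccc2-c2nn[nH]n2)cc1` differs from compound 2 by methyl in place of 4-methylphenyl on a sulfonyl sulfur. Among the measured compounds shown here, only the step from compound 1 to compound 2 bears on this position, and it was flat, which suggests tolerance there, though no measured pair removes the aromatic ring. For compound 3 a small step of a 1.7-fold higher number from compound 2 to compound 3 (0.22 log units; within the scatter) toward a weaker inhibitor is expected, with an estimate of 15 nM in this assay, range 5 nM to 60 nM.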

Compound 3, half-maximal inhibitory concentration: 2 nM
Beside the measured number, compound 3's estimate is 7.5-fold (0.88 log units) above it; measured number below the stated range.
By their numbers in this assay, from the lowest: compound 3; then compounds 2 and 1 (each within the scatter of the next).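

In this assay the group on the sulfonyl sulfur does matter: the step of a 4.5-fold lower number from compound 2 to compound 3 (0.65 log units; beyond the scatter) for methyl in place of 4-methylphenyl shows a change that the earlier exchange of caps did not. The comparison with the tert-butoxycarbonyl cap points the same way with a 5.0-fold lower number from compound 1 to compound 3 (0.70 log units; beyond the scatter) and shows that the aromatic ring of 4-methylphenyl is not needed to reach this level. No supporting data here explain this gain.

Still open, from the compounds shown here alone, is whether an ethyl group or a longer chain on the sulfonyl sulfur holds this level, and whether a free amine can replace the sulfonamide.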